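Changing the Sulfonyl Aryl Group of Compound 2

The source may report more compounds than this note shows. Statements on the series, on what has been measured and on what is new or still open speak of the compounds shown alone.

Compound 1, `Cc1ccc(C)c(S(=O)(=O)n2c(-c3cn(-c4ccccc4)nc3-c3ccc(F)cc3)nc3ccccc32)c1`: 320 nM
Compound 2, `Cc1ccc(C)c(S(=O)(=O)n2c(-c3cn(-c4ccccc4)nc3-c3ccc(C(F)(F)F)cc3)nc3ccccc32)c1`: 210 nM

In a functional assay on HeLa cells (Homo sapiens) for antiproliferative activity, read by MTT assay, with a stated time of 24 h (a lower number here means a stronger inhibitor, a higher number a weaker inhibitor), compound 2 gives the lowest of the two numbers recorded so far; its nearest neighbour is compound 1, and the step between them, a 1.5-fold lower number from compound 1 to compound 2 (0.18 log units; within the scatter), does not separate the two. Compound 3, `O=S(=O)(c1ccc(C(F)(F)F)cc1)n1c(-c2cn(-c3ccccc3)nc2-c2ccc(C(F)(F)F)cc2)nc2ccccc21`, differs from compound 2 in one place: 4-(trifluoromethyl)phenyl in place of 2,5-dimethylphenyl on a sulfonyl sulfur. Among the measured compounds shown here, no measured step touches the group on the sulfonyl sulfur; the single step seen, a 1.5-fold lower number from compound 1 to compound 2 (0.18 log units; within the scatter), concerns a different site and was small, so it bears on the present change only by showing that a single substituent exchange moved the number little. On that basis the step is expected to be a 1.2-fold higher number from compound 2 to compound 3 (0.08 log units; within the scatter), nothing beyond the scatter. Compound 3 is therefore estimated at 250 nM, within a range from 100 nM to 600 nM.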

Compound 3, half-maximal inhibitory concentration: 970 nM
Estimate against measurement, compound 3: 3.9-fold (0.59 log units) below, and the stated range ends below it.
By their numbers in this assay, from the lowest: compounds 2 and 1 (each within the scatter of the next); then compound 3.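

The group on the sulfonyl sulfur matters in this assay: 4-(trifluoromethyl)phenyl in place of 2,5-dimethylphenyl gives a 4.6-fold higher number from compound 2 to compound 3 (0.66 log units; beyond the scatter), so this compound is a weaker inhibitor. Among the compounds shown here, this is the first step to lie beyond the scatter, whereas the exchange at the other site, a 1.5-fold lower number from compound 1 to compound 2 (0.18 log units; within the scatter), did not separate its two compounds. No measurement at hand accounts for the change at the sulfonyl sulfur.

The exchange removes two methyl groups and brings in one trifluoromethyl group at once, so the compounds shown do not tell which part of it carries the step. From the compounds shown here alone, it also remains open how an unsubstituted phenyl, a methoxyphenyl or an aminophenyl on the sulfonyl sulfur would compare with the 2,5-dimethylphenyl of compound 2.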